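Amide tail swap in the cytotoxicity screen, compound 3

A few compounds are considered here, and "the series" means these few. Any claim that something is new, unique, unknown or untested is made for them only; others in the source may bear on it.

Compound 2 `CCC(=O)Nc1ccc(-c2nc3cc(C(F)(F)F)ccc3n2C)cc1` gives only a limit in an ADME assay on MDBK cells (Bos taurus) for cytotoxicity, read by MTT assay, with a stated time of 96 h (on this read-out lower numbers stand for higher toxicity in this test and higher numbers for lower toxicity in this test), namely > 100000 nM. Compound 1 `Cn1c(-c2ccc(NC(=O)CN3CCCC3)cc2)nc2cc(C(F)(F)F)ccc21` gives 65000 nM in this assay. Among the measured compounds shown here, the single measured change on a saturated chain carbon bound to a carbonyl carbon is an at least 1.5-fold higher number from compound 1 to compound 2 (0.18 log units; that floor lies within the scatter), bounded by the limit of > 100000 nM in this assay, at which 1 of the 2 values shown sits. Compound 3 `Cn1c(-c2ccc(NC(=O)CN3CCN(c4ccccc4)CC3)cc2)nc2cc(C(F)(F)F)ccc21` differs from compound 2 by 4-phenylpiperazin-1-yl in place of methyl on a saturated chain carbon bound to a carbonyl carbon. For the measured compounds named here, with that one small step as the only guide, for compound 3 a modest downward step an at least 2.0-fold lower number from compound 2 to compound 3 (0.30 log units; that floor lies within the scatter) is expected in this assay, bringing the number back into the measurable range. Compound 3 is estimated at 50000 nM, between 15000 nM and 150000 nM.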

Compound 3, half-maximal cytotoxic concentration: 1400 nM
The estimate for compound 3 lay 36-fold (1.55 log units) above the measured number; the whole stated range lies above it.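

In this assay, this place on a saturated chain carbon bound to a carbonyl carbon now carries large steps, where the earlier swap gave only a floor within the scatter. Against pyrrolidin-1-yl, 4-phenylpiperazin-1-yl gives a 46-fold lower number from compound 1 to compound 3 (1.67 log units; beyond the scatter). Against methyl it gives an at least 71-fold lower number from compound 2 to compound 3 (1.85 log units; beyond the scatter), a floor only, since compound 2 stands at a limit: the limit of > 100000 nM in this assay, at which 1 of the 3 values shown sits.

The compounds shown do not separate the phenyl part of 4-phenylpiperazin-1-yl from its piperazine part. A 4-methylpiperazin-1-yl or benzylamino group at this place would bear on that question.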